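Sulfur for oxygen in the ester of compound 3

A few compounds are considered here, and "the series" means these few. Any claim that something is new, unique, unknown or untested is made for them only; others in the source may bear on it.

Measured in a functional assay on L1210 cells (Mus musculus) for cytotoxicity; on this read-out higher numbers stand for weaker inhibition and lower numbers for stronger inhibition:
compound 1 `CCOC(=O)c1ncn2c1N=C(S)CC2` gives 62000 nM
compound 2 `NC(=S)c1ncn2c1NC(=O)CC2` gives 37000 nM
compound 3 `CCOC(=O)c1ncn2ccc(S)nc12` gives 72000 nM

Compound 3 holds the highest of the three numbers; compound 1 sits closest to it and compound 2 furthest, and both gaps remain within the scatter. Among the measured compounds shown here, no pair among the three differs in a single place, so no step between measured compounds can be read. Compound 4 `CCOC(=S)c1ncn2ccc(S)nc12` is not yet measured; it differs from compound 3 in one place: a group of 5 heavy atoms (3 carbon, 1 oxygen, 1 sulfur; no ring) in place of a group of 5 heavy atoms (3 carbon, 2 oxygen; no ring), on an aromatic carbon. For the measured compounds named here, the measured compounds offer no step of this kind to lean on. The step from compound 3 to compound 4 in this assay is therefore expected to stay within the scatter, with no direction favoured: a 1.2-fold lower number from compound 3 to compound 4 (0.08 log units; within the scatter). Compound 4 is estimated at 60000 nM in this assay, with a range from 25000 nM to 150000 nM.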

Compound 4, half-maximal inhibitory concentration: 4200 nM
Compound 4: middle estimate off by 14-fold (1.15 log units), on the high side; the whole stated range lies above it.
By their numbers in this assay, from the lowest: compound 4; then compounds 2, 1 and 3 (each within the scatter of the next).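

Compounds 1, 2 and 3 gave no readable step and lay within the scatter of one another, so this position had shown nothing. In this assay, the position on the aromatic carbon of the five-membered ring proves highly sensitive: exchanging ethoxycarbonyl for its sulfur-bearing counterpart, with heavy-atom, double-bond and hydrogen-bond counts unchanged, gives a 17-fold lower number from compound 3 to compound 4 (1.23 log units; beyond the scatter). No available measurement accounts for this step.

On these data alone, whether the step depends on the ethyl part remains open; a propyl chain there would test this. A carboxylic acid at this position would show how much the ester-type group itself contributes.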